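From 2-(trifluoromethyl)benzyl to 3-chlorobenzyl: a small expected step

The compounds below may be only part of what the source reports. "The series", "measured", "known", "first", "only" and "open" are said of these compounds alone.

Of the compounds shown here, three with a shared core have been measured in a functional assay on HCT-116 cells (Homo sapiens) for antiproliferative activity, read by MTT assay, with a stated time of 24 h; a higher number here means a weaker inhibitor, a lower number a stronger inhibitor. Compound 1 `C#CCOc1ccc2c(=O)c(-c3cc(OC)c(OC)cc3OC)coc2c1` gives 8050 nM, compound 2 `COc1cc(OC)c(-c2coc3cc(OCc4ccccc4F)ccc3c2=O)cc1OC` gives 2900 nM, and compound 3 `COc1cc(OC)c(-c2coc3cc(OCc4ccccc4C(F)(F)F)ccc3c2=O)cc1OC` gives 4760 nM. Compound 3 lies inside the span set by the other two, and its gaps to both are small: a 1.7-fold lower number from compound 1 to compound 3 (0.23 log units; within the scatter), and a 1.6-fold higher number from compound 2 to compound 3 (0.22 log units; within the scatter).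

Compound 4 `COc1cc(OC)c(-c2coc3cc(OCc4cccc(Cl)c4)ccc3c2=O)cc1OC` has not yet been measured. It differs from compound 3 in one place: 3-chlorophenyl in place of 2-(trifluoromethyl)phenyl on a saturated chain carbon bound to an oxygen on an aromatic ring. This puts 3-chlorophenyl in place of 2-(trifluoromethyl)phenyl on a saturated chain carbon bound to an oxygen on an aromatic ring.

Within the data shown here, no measured pair makes this exact swap, and no measured compound carries 3-chlorophenyl. Among the measured compounds shown here, the closest guides are the steps above, where the group on the aromatic ring changes between compound 2 and compound 3, and the one modest step in the set, a 2.8-fold lower number from compound 1 to compound 2 (0.44 log units; beyond the scatter), which replaces ethynyl altogether. Swapping one substituted phenyl for another has so far stayed within the scatter, so no step beyond it is expected, and the direction remains open.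

The estimated step is small: a 1.3-fold lower number from compound 3 to compound 4 (0.11 log units; within the scatter). For compound 4 the expected value is 3700 nM, with an estimated range of 1700 nM to 8000 nM.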

Compound 4, half-maximal inhibitory concentration: 1330 nM
Compound 4: middle estimate off by 2.8-fold (0.44 log units), on the high side, outside the stated range (below it).
By their numbers in this assay, from the lowest: compound 4; then compounds 2, 3 and 1 (each within the scatter of the next, the first and the last beyond it).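

In this assay the earlier swap of one substituted phenyl for another, from compound 2 to compound 3, stayed within the scatter, but this swap gives a 3.6-fold lower number from compound 3 to compound 4 (0.55 log units; beyond the scatter) and a 2.2-fold lower number from compound 2 to compound 4 (0.34 log units; beyond the scatter) and so shows that the choice of phenyl group on this saturated chain carbon can move the number beyond it. Compound 4 now has the lowest number of the four, with its steps to all three others beyond the scatter, and replacing the ethynyl of compound 1 gives a 6.1-fold lower number from compound 1 to compound 4 (0.78 log units; beyond the scatter) as the largest step in the set. No measurement at hand explains why 3-chlorophenyl gives the lower number.

From the compounds shown here alone, it stays open whether the chlorine or its place on the ring matters more: 3-chlorophenyl differs from both 2-fluorophenyl and 2-(trifluoromethyl)phenyl in the substituent and in its place at once. Going by these compounds, how an amine or a carboxylic acid on this phenyl ring, or a longer chain in place of the benzyl link, would read in this assay also stays open.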